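The Same Small Change on Two Different Cores

A few compounds are considered here, and "the series" means these few. Any claim that something is new, unique, unknown or untested is made for them only; others in the source may bear on it.

Compound 1 `Cc1cnn(C(=O)N2CCCN(Cc3ccc(OCc4ccccc4)cc3)CC2)c1` and compound 2 `O=C(N1CCCN(Cc2ccc(OCc3ccccc3)cc2)CC1)n1cccn1` share one core. Compound 3 `Cc1cnn(C(=O)N(C)CCN(C)C(c2ccc(OCc3ccccc3)cc2)c2ccc(OCc3ccccc3)cc2)c1` and compound 4 `CN(CCN(C)C(c1ccc(OCc2ccccc2)cc1)c1ccc(OCc2ccccc2)cc1)C(=O)n1cccn1` share a second core, and the difference between the two cores is not broken down here. In an assay on membranes from brain for binding affinity to Fatty-acid amide hydrolase 1 (Mus musculus), read by fluorescence, with stated times of 1 h and 30 min (a lower number here means a stronger inhibitor, a higher number a weaker inhibitor), compound 1 gives 560 nM, and in this assay compound 2 gives 450 nM. The change between them is hydrogen in place of methyl on an aromatic carbon, and it produced a 1.2-fold lower number from compound 1 to compound 2 (0.09 log units; within the scatter). On this core, then, the two compounds sit at about the same level.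

For compound 3 the this assay reports only a limit, > 1000000 nM. That reading is the limit of > 1000000 nM in this assay, at which 1 of the 3 values shown sits.

The change from compound 3 to compound 4 is the same one: hydrogen in place of methyl on an aromatic carbon. Among the compounds with values here, only one measured example of it exists, the pair on the first core, and there the effect was too small to separate from repeat-to-repeat noise. Within the data shown here, compound 4 is therefore expected to behave like compound 3, because the single measured instance of this change, a 1.2-fold lower number from compound 1 to compound 2 (0.09 log units; within the scatter), stayed within the scatter. The expected step is a number no higher from compound 3 to compound 4 (the limit leaves the size open), which is to say essentially no movement. The estimate for compound 4 in the this assay is 1000000 nM, with a plausible span from 300000 nM to 3000000 nM. Most likely, compound 4 will again be reported only as a limit rather than as a number.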

Compound 4, half-maximal inhibitory concentration: > 1000000 nM
Compound 4: no number, only a limit; the forecaster's own chance of this, stated with the estimate: 85%; the middle value sits exactly at the limit.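

Within the data shown here, compound 4, like compound 3, is reported in this assay only as a limit, not a number, so no step between them can be read. The result is a shared reading: the limit of > 1000000 nM in this assay, at which 2 of the 4 values shown sit.

The compounds shown leave open what real numbers lie behind these two limits, and so whether going from 4-methyl-1H-pyrazol-1-yl to 1H-pyrazol-1-yl changes anything on this second core.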